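A few compounds are considered here, and "the series" means these few. Any claim that something is new, unique, unknown or untested is made for them only; others in the source may bear on it.

Measured compounds:
compound 1 `O=C(Nc1cccc(-n2cc(-c3ccncc3)c(-c3ccc(Cl)c(O)c3)n2)c1)Nc1cccc(C(F)(F)F)c1`, 509 nM
compound 2 `O=C(Nc1cccc(-n2cc(-c3ccncc3)c(-c3ccc(Cl)c(O)c3)n2)c1)Nc1ccc(Cl)c(Cl)c1`, 679 nM
compound 3 `COc1cc(-c2nn(-c3cccc(NC(=O)Nc4ccc(Cl)c(C(F)(F)F)c4)c3)cc2-c2ccncc2)ccc1Cl`, 499 nM

In a functional assay on HOP-92 cells (Homo sapiens) for inhibition, read by sulforhodamine B assay, with a stated time of 48 h (a lower number here means a stronger inhibitor of growth, a higher number a weaker inhibitor of growth), compound 3 gives the lowest of the three numbers, yet its gaps to compound 1 and compound 2 lie within the scatter, so the three stand level. Compound 4 `O=C(Nc1cccc(-n2cc(-c3ccncc3)c(-c3ccc(Cl)c(O)c3)n2)c1)Nc1ccc(Cl)c(C(F)(F)F)c1` differs from compound 3 in one place: hydrogen in place of methyl on an oxygen on an aromatic ring. Going by the values given here, no measured pair shows this exact change. Among the compounds with values here, the only step available, a 1.3-fold higher number from compound 1 to compound 2 (0.13 log units; within the scatter), concerns a different part of the molecule and stays within the scatter. Compound 1 and compound 2, which already carry the hydroxy group, give numbers close to compound 3. The step from compound 3 to compound 4 is therefore expected to be a 1.1-fold higher number from compound 3 to compound 4 (0.04 log units; within the scatter), no change beyond the scatter. Compound 4 is expected to give 550 nM, between 250 nM and 1200 nM.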

Compound 4, concentration for 50% growth inhibition: 376 nM
For compound 4 the middle estimate is 1.5-fold (0.17 log units) above the measured one; the measured number falls inside the stated range.
By their numbers in this assay, from the lowest: compounds 4, 3, 1 and 2 (each within the scatter of the next).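

In this assay, going by these compounds alone, the change from methoxy to hydroxy gives a 1.3-fold lower number from compound 3 to compound 4 (0.12 log units; within the scatter) and so leaves the number level, the first direct reading of this swap at this position. On an aromatic carbon elsewhere, trifluoromethyl in place of chloro gives a 1.8-fold lower number from compound 2 to compound 4 (0.26 log units; within the scatter) and chloro in place of hydrogen gives a 1.4-fold lower number from compound 1 to compound 4 (0.13 log units; within the scatter) with the same outcome. No measurement here says why these changes leave the number level. Still open, from the compounds shown here alone, is whether an amine or an ethoxy group in place of the hydroxy would move the number beyond the scatter.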